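This account rests on a few compounds, and the source may have more. Where it says the series, first, only, none or still open, it means among the compounds named here.

Working notes on the series. The shared core carries a phenoxy group whose oxygen bears the variable substituent. Compound 1 `C=C(C)C(=O)NCCOc1ccc(Oc2c(-c3ccc(F)cc3)sc3cc(O)ccc23)cc1` carries 2-(((1-methylethenyl)carbonyl)amino)ethyl on that oxygen. In a functional assay on MCF7 cells (Homo sapiens) for antiproliferative activity, read by CCK-8 assay, with a stated time of 48 h (a higher number here means a weaker inhibitor, a lower number a stronger inhibitor), compound 1 gives > 25000 nM, which is a limit of the assay and not a number. Compound 2 `CN(C)C(=O)/C=C/CN1CC(Oc2ccc(Oc3c(-c4ccc(F)cc4)sc4cc(O)ccc34)cc2)C1` carries 1-(3-(dimethylcarbamoyl)prop-2-en-1-yl)azetidin-3-yl on the same oxygen, and in this assay compound 2 gives 22300 nM. The step of an at least 1.1-fold lower number from compound 1 to compound 2 (0.04 log units; that floor lies within the scatter) rests on the limit of > 25000 nM in this assay, at which 1 of the 2 values shown sits, and cannot be read as a real change.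

Compound 3 `C/C=C/C(=O)N1CC(Oc2ccc(Oc3c(-c4ccc(F)cc4)sc4cc(O)ccc34)cc2)C1` is not yet measured in this assay. It differs from compound 1 in one place: 1-((prop-1-en-1-yl)carbonyl)azetidin-3-yl in place of 2-(((1-methylethenyl)carbonyl)amino)ethyl on an oxygen on an aromatic ring. Going by the values given here, the only measured step that bears on this move is the swap to the azetidine in compound 2, which stayed within the scatter, so no step beyond the scatter is expected in this assay for compound 3 either. Compound 3 is therefore expected to give about 25000 nM in this assay, with a range from 10000 nM to 60000 nM, and a further limit rather than a number is likely. The expected step of a number no higher from compound 1 to compound 3 (the limit leaves the size open) is thus essentially flat.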

Compound 3, half-maximal inhibitory concentration: 28000 nM
The estimate for compound 3 lay 1.1-fold (0.05 log units) below the measured number; low and high end bracket the measured number.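

Going by these compounds alone, with compound 3, the azetidin-3-yl on the oxygen can for the first time be compared on two real numbers, with the substituent changing on an amine nitrogen in a ring. In this assay, (prop-1-en-1-yl)carbonyl in place of 3-(dimethylcarbamoyl)prop-2-en-1-yl gives a 1.3-fold higher number from compound 2 to compound 3 (0.10 log units; within the scatter), so this exchange does not separate the two compounds, and a carbonyl directly on that nitrogen reads no differently here from the longer substituent of compound 2. Compound 1 stands at a limit and not at a number, and the step from compound 1 to compound 3 cannot be read because of that limit: the limit of > 25000 nM in this assay, at which 1 of the 3 values shown sits.

Still open, going by these compounds, is whether any other group on the azetidine nitrogen, such as a plain propenoyl, a 4-(dimethylamino)but-2-enoyl or a simple methyl, would move the number in this assay beyond the scatter. On these data alone, it is equally open whether a piperidine ring in place of the azetidine, or a longer chain ending in an amine or a carboxylic acid on the oxygen, would do so.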